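This account rests on a few compounds, and the source may have more. Where it says the series, first, only, none or still open, it means among the compounds named here.

Measured so far in an ADME assay on microsomes from liver (Rattus norvegicus) for metabolic stability, read by LC-MS, using NADPH, with a stated time of 30 min, tested at 0.1 uM; on this read-out higher numbers stand for a more stable compound and lower numbers for a less stable compound:
compound 1 `O=S(=O)(c1cccc(-c2ccc3nccc(-c4ccncc4)c3n2)c1)N1CCC(O)CC1`: 11%
compound 2 `O=S(=O)(NCCO)c1cccc(Nc2ccc3nccc(-c4ccncc4)c3n2)c1`: 58%

Of these two, compound 1 stands lower, and compound 2 lies above it by a gap beyond the usual scatter of such measurements. Compound 3 `Nc1cccc(-c2ccc3nccc(-c4ccncc4)c3n2)c1` has not yet been measured. It keeps the rest of compound 1 but carries amino in place of (4-hydroxypiperidin-1-yl)sulfonyl on an aromatic carbon. Within the data shown here, no measured pair shows a single change of this kind, so any forecast is a judgement. Compound 1 at 11% has little room to fall in this assay, while compound 2 at 58% shows that a much higher number is possible in this small set. The expected change is upward and beyond the scatter, an estimated a number 19 percentage points higher from compound 1 to compound 3 (beyond the scatter). For compound 3 the estimated value is 30%, with an expected range from 10% to 60%.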

Compound 3, percent of the compound remaining: 61%
The estimate for compound 3 lay 31 percentage points below the measured number; the measured number lies above the stated range.
By their numbers in this assay, from the lowest: compound 1; then compounds 2 and 3 (each within the scatter of the next).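

In this assay, swapping the (4-hydroxypiperidin-1-yl)sulfonyl group for amino on this aromatic carbon gives a number 50 percentage points higher from compound 1 to compound 3 (beyond the scatter). Among these compounds, this is the first single-place comparison in the set, and it shows that the group at this position can by itself move the number by far more than the scatter while the shared core stays the same. Nothing measured here explains the rise, so the structures show only that it happens.

The change removes a group of 10 heavy atoms in one go, so the compounds shown leave open whether the sulfonyl, the non-aromatic ring or its hydroxyl matters most. An acetamide or a methoxy at the same carbon, or a sulfonyl carrying a plain piperidine, could help separate these parts.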